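The source may report more compounds than this note shows. Statements on the series, on what has been measured and on what is new or still open speak of the compounds shown alone.

Compound 1, `O=C1CCC(N2C(=O)c3cccc(Nc4ccccn4)c3C2=O)C(=O)N1`, is one of three compounds tested in an assay on FRT-Jurkat cells for inhibition of nuclear factor NF-kappa-B complex (Homo sapiens), read by flow cytometry, with a stated time of 24 h, tested at 10 uM; a lower number here means less inhibition, a higher number more inhibition at the concentration tested (going by the name of the read-out). There compound 1 gives 1%. Compound 2, `O=C1CCC(N2C(=O)c3ccc(Nc4ccc(O)cc4)cc3C2=O)C(=O)N1`, gives 4%, within the scatter of compound 1, while compound 3, `CCCCCc1ccc(Nc2ccc3c(c2)C(=O)N(C2CCC(=O)NC2=O)C3=O)cc1`, gives 12%, beyond the scatter of compound 1. Compound 4, `CCc1ccc(Nc2cccc3c2C(=O)N(C2CCC(=O)NC2=O)C3=O)cc1`, has not been measured; it differs from compound 1 in one place: 4-ethylphenyl in place of pyridin-2-yl on a nitrogen on an aromatic ring. For the measured compounds named here, the only measured step, a number 8 percentage points higher from compound 2 to compound 3 (within the scatter), changes a group on an aromatic carbon and stays within the scatter, and nothing measured touches a pyridin-2-yl group. Going by the values given here, with no step bearing directly on this change, no movement beyond the scatter is expected. Compound 4 is estimated at 5%, in the range -5% to 15%, meaning an expected a number 4 percentage points higher from compound 1 to compound 4 (within the scatter).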

Compound 4, a percentage reported as inhibition, at one concentration (the size of the read-out at that concentration, not a potency): 17%
Compound 4: middle estimate off by 12 percentage points, on the low side, outside the stated range (above it).
By their numbers in this assay, from the lowest: compounds 1, 2, 3 and 4 (each within the scatter of the next, the first and the last beyond it).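

In this assay, 4-ethylphenyl in place of pyridin-2-yl on this nitrogen gives a number 16 percentage points higher from compound 1 to compound 4 (beyond the scatter). It is the only step shown that lies beyond the scatter, so the group at this position can move the read-out, although only one concentration was tested. Nothing available explains why this change has that effect. The step replaces the ring nitrogen and adds the ethyl group together, so the compounds shown cannot separate the two changes. A plain phenyl group on the same nitrogen would fall between compound 1 and compound 4 in structure and could tell them apart.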